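Replacing 4-Nitrophenyl with 3-Methylphenyl in a Shared Core

The source may hold more compounds than are shown below. What is called first, only, known or untested is meant among the compounds shown, and "the series" means these compounds.

Compound 1 `O=C(NCc1ccc(CNS(=O)(=O)c2ccccc2)cc1)c1ccc(F)cc1`: 100 nM
Compound 2 `O=C(NCc1ccc(CNS(=O)(=O)c2ccccc2)cc1)c1cccnc1`: 10 nM
Compound 3 `O=C(NCc1ccc(CNS(=O)(=O)c2ccccc2)cc1)c1ccc([N+](=O)[O-])cc1`: 100 nM

All three compounds share one core and differ only in the group on the carbonyl carbon. In an assay on MDA-MB-231 cells for binding affinity to C-X-C chemokine receptor type 4 (Homo sapiens), read by immunofluorescence and microscopy, with stated times of 10 min and 30 min (a higher number here means that more compound is needed for the effect, a lower number that less compound is needed), compound 3 stands level with compound 1, the pair giving the highest numbers, while the step of a 10-fold higher number from compound 2 to compound 3 (1.00 log units; beyond the scatter) separates it from compound 2.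

Compound 4 `Cc1cccc(C(=O)NCc2ccc(CNS(=O)(=O)c3ccccc3)cc2)c1` is the next step: 3-methylphenyl in place of 4-nitrophenyl on a carbonyl carbon. Among the compounds with values here, two measured steps bear on it. The step of no change at the digits printed from compound 1 to compound 3 (within the scatter) shows that exchanging one substituent for another on a carbon-only ring left the number unmoved, whereas a 10-fold lower number from compound 1 to compound 2 (1.00 log units; beyond the scatter) shows that exchanging the ring itself did shift it. Compound 4 keeps a carbon-only ring, so the expected step is no change at the digits printed from compound 3 to compound 4 (within the scatter), within the scatter. Compound 4 is therefore estimated at 100 nM, with a range from 30 nM to 300 nM.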

Compound 4, effective concentration (reported as EC, without a stated level of effect): 1000 nM
Compound 4: middle estimate off by 10-fold (1.00 log units), on the low side; measured number outside the range, above it.
By their numbers in this assay, from the lowest: compound 2; then compounds 1 and 3 (each within the scatter of the next); then compound 4.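

In this assay, a carbon-only ring on the carbonyl carbon does not fix the number, as shown by a 10-fold higher number from compound 3 to compound 4 (1.00 log units; beyond the scatter) and by a 10-fold higher number from compound 1 to compound 4 (1.00 log units; beyond the scatter), so the substituent on such a ring can matter here. The widest gap among these compounds is now a 100-fold higher number from compound 2 to compound 4 (2.00 log units; beyond the scatter) and it separates pyridin-3-yl from 3-methylphenyl. No measurement at hand accounts for these shifts. As far as these compounds go, it remains open whether the higher number follows the methyl group itself or its place on the ring, which 4-methylphenyl could test. A phenyl ring carrying an amine or a carboxylic acid also remains an open case.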